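The source may hold more compounds than are shown below. What is called first, only, known or untested is meant among the compounds shown, and "the series" means these compounds.

Measured so far:
compound 1, `COc1cc(C=C2C(=O)N(c3ccc(Cl)cc3)N(c3ccc(Cl)cc3)C2=O)cc(OC)c1OC`, 29500 nM
compound 2, `O=C1C(=Cc2cccc(Cl)c2)C(=O)N(c2ccc(Cl)cc2)N1c1ccc(Cl)cc1`, 20200 nM
compound 3, `CC(=C1C(=O)N(c2ccc(Cl)cc2)N(c2ccc(Cl)cc2)C1=O)c1ccc(O)cc1`, 57000 nM

All three were tested in a functional assay on SMMC-7721 cells (Homo sapiens) for cytotoxicity, read by MTT assay, with a stated time of 72 h; on this read-out higher numbers stand for weaker inhibition and lower numbers for stronger inhibition. Compound 2 has the lowest of the three numbers; compound 1 sits within the scatter of it, while compound 3 lies beyond the scatter, with a higher number. Compound 4, `O=C1C(=Cc2ccccc2)C(=O)N(c2ccc(Cl)cc2)N1c1ccc(Cl)cc1`, has not yet been measured. It differs from compound 2 in one place: hydrogen in place of chloro on an aromatic carbon. Going by the values given here, no measured pair shows this exact change, so its effect is not known from these data. With only a chloro taken off an aromatic carbon and nothing else altered, little movement beyond the scatter is expected in either direction for the step of a 1.4-fold higher number from compound 2 to compound 4 (0.14 log units; within the scatter). Compound 4 is therefore expected to give about 28000 nM, within a range from 12000 nM to 65000 nM.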

Compound 4, half-maximal inhibitory concentration: 26200 nM
Compound 4: middle estimate off by 1.1-fold (0.03 log units), on the high side; the range from low to high includes it.
By their numbers in this assay, from the lowest: compounds 2, 4, 1 and 3 (each within the scatter of the next, the first and the last beyond it).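

Going from 3-chlorophenyl to phenyl in this assay gives a 1.3-fold higher number from compound 2 to compound 4 (0.11 log units; within the scatter) and so offers the first direct reading of this change. At this place on the aromatic ring, the chloro can be removed without the number leaving the scatter, so the chloro is not needed to keep this level of cytotoxicity. Nothing available explains why the change makes so little difference.
From the compounds shown here alone, whether an amine or a carboxylic acid at this place would shift the number beyond the scatter remains open. So does whether removing the chloro would have as little effect on a different core.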